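Pyridine nitrogen moved: compound 2 to compound 3

The source may hold more compounds than are shown below. What is called first, only, known or untested is meant among the compounds shown, and "the series" means these compounds.

Compound 2 `Cc1cc(Oc2ccc(Cn3nc4ccc(Cl)cc4c3C(=O)NS(=O)(=O)c3ccc([N+](=O)[O-])c(NCc4cccnc4)c3)cc2)cc(C)c1Cl` stands at 1220 nM in an assay on isolated protein for inhibition of Apoptosis regulator Bcl-2 (Homo sapiens), read by fluorescence polarization (a lower number here means a stronger inhibitor, a higher number a weaker inhibitor), alongside compound 1 `Cc1cc(Oc2ccc(Cn3nc4ccc(Cl)cc4c3C(=O)NS(=O)(=O)c3ccc([N+](=O)[O-])c(NCc4ccco4)c3)cc2)cc(C)c1Cl` at 960 nM; the step of a 1.3-fold higher number from compound 1 to compound 2 (0.10 log units; within the scatter) is within the scatter. Compound 3 `Cc1cc(Oc2ccc(Cn3nc4ccc(Cl)cc4c3C(=O)NS(=O)(=O)c3ccc([N+](=O)[O-])c(NCc4ccncc4)c3)cc2)cc(C)c1Cl` differs from compound 2 by pyridin-4-yl in place of pyridin-3-yl on a saturated chain carbon bound to a nitrogen on an aromatic ring. Among the measured compounds shown here, the only step that bears on this position, a 1.3-fold higher number from compound 1 to compound 2 (0.10 log units; within the scatter), exchanged whole heteroaryl groups and stayed within the scatter; a shift of the ring nitrogen within the same pyridine is a smaller change, so for compound 3 no step beyond the scatter is expected, a 1.0-fold lower number from compound 2 to compound 3 (0.01 log units; within the scatter). Compound 3 is therefore estimated at 1200 nM, with a range from 600 nM to 2400 nM.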

Compound 3, inhibition constant: 710 nM
Compound 3: the middle estimate sits 1.7-fold (0.23 log units) above what was measured; the range from low to high includes it.
By their numbers in this assay, from the lowest: compounds 3, 1 and 2 (each within the scatter of the next).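

In this assay, the step of a 1.7-fold lower number from compound 2 to compound 3 (0.24 log units; within the scatter) and the step of a 1.4-fold lower number from compound 1 to compound 3 (0.13 log units; within the scatter) both stay within the scatter. On this saturated chain carbon, compound 1, compound 2 and compound 3 cannot be separated, so moving the pyridine nitrogen, like exchanging the furan-2-yl, gives no readable change. No measurement at hand explains how close these values lie.

Still open, going by these compounds, is whether a non-aromatic group at this place, such as a piperidine or a carboxylic acid, would give a step beyond the scatter. The same question stands for a longer chain between the aromatic ring and the amino nitrogen.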